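The source may report more compounds than this note shows. Statements on the series, on what has been measured and on what is new or still open speak of the compounds shown alone.

Measured compounds in the series so far:

compound 1 `O=C(O)COCCCC[C@H]1[C@H](F)CC[C@@H]1NS(=O)(=O)c1ccc(F)cc1F` gives 1800 nM
compound 2 `O=C(O)COCCCC[C@H]1[C@H](F)CC[C@@H]1NS(=O)(=O)c1ccc(F)cc1` gives 1800 nM
compound 3 `O=C(O)CC/C=C\CC1=CCC[C@@H]1NS(=O)(=O)c1ccc(F)cc1F` gives 20000 nM

All three numbers come from a functional assay on a cell-free system (plasma) for inhibition of thromboxane A2 receptor (Homo sapiens), read by turbidimetry; on this read-out lower numbers stand for stronger inhibition and higher numbers for weaker inhibition. Compound 1 and compound 2 share one core and differ only by the change (hydrogen in place of fluoro on an aromatic carbon); the step of no change at the digits printed from compound 1 to compound 2 (within the scatter) shows this change leaves the read-out where it was. Compound 3 sits on a different core; the difference between the two cores is not broken down here. Compound 3 stands apart from compound 1 and from compound 2 by a gap well beyond the scatter, at the weak end of the set.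

Compound 4 `O=C(O)CC/C=C\CC1=CCC[C@@H]1NS(=O)(=O)c1ccc(F)cc1` is not yet measured. Within the data shown here, it relates to compound 3 as compound 2 relates to compound 1: the change hydrogen in place of fluoro on an aromatic carbon is the same as the one between compound 1 and compound 2, with the same surroundings around the place. Among the measured compounds shown here, the one prior example of this change within this assay, the step from compound 1 to compound 2, did not move the number, so the step from compound 3 to compound 4 is expected to be about as flat, no change at the digits printed from compound 3 to compound 4 (within the scatter), resting on the value of compound 3 20000 nM as the starting point. For the measured compounds named here, the single precedent is only one pair, so the range around the expectation is kept broad. For compound 4 the estimated value in this assay is 20000 nM, with the expected range from 8000 nM to 50000 nM.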

Compound 4, half-maximal inhibitory concentration: 1300 nM
Beside the measured number, compound 4's estimate is 15-fold (1.19 log units) above it; measured number outside the range, below it.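

In this assay, the exchange of 2,4-difluorophenyl for 4-fluorophenyl does not transfer as a constant increment between the two cores: the same change on two cores in this assay, no change at the digits printed (within the scatter) from compound 1 to compound 2 and a 15-fold lower number (1.19 log units; beyond the scatter) from compound 3 to compound 4, 15-fold (1.19 log units) apart, beyond the scatter of two such steps On the core of compound 3, the change gives a 15-fold lower number from compound 3 to compound 4 (1.19 log units; beyond the scatter), whereas on the core of compound 1 it gives no change at the digits printed from compound 1 to compound 2 (within the scatter), so the flat result from the first pair cannot be used to predict the second in this series. Among these compounds, this shows that the effect of this change depends on the core carrying it, but with only two pairs and two cores that differ in more than one place, it does not show which feature of the core is responsible, nor how the change would behave on any third core.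

The compounds shown leave open whether the large step on the core of compound 3 is specific to the fluoro group or would also appear with a chloro or methyl group at the same aromatic carbon. They also leave open how the core of compound 3 would respond if its carboxylic acid were replaced by a tetrazole, or if its chain were made longer.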